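Swapping the piperidine arm of compound 2

A few compounds are considered here, and "the series" means these few. Any claim that something is new, unique, unknown or untested is made for them only; others in the source may bear on it.

Going by the values given here, compound 2 `N#CC1CCN(c2nccnc2OC2CN(c3ccc4ccccc4n3)C2)CC1` is the more soluble of the two compounds measured so far. In a physicochemical assay for solubility, in phosphate buffer, at pH 7.4 (on this read-out higher numbers stand for higher solubility and lower numbers for lower solubility), compound 2 gives 66000 nM, the highest of the two numbers recorded. Among the compounds with values here, its nearest neighbour, compound 1 `OCC1CCN(c2nccnc2Oc2ccc(Nc3nc4ccccc4s3)cc2)CC1`, gives 6000 nM in this assay, a gap that lies beyond the usual scatter; the two differ in several places at once, so their values show only that compound 2 stands well above compound 1.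

Compound 3 `CS(=O)(=O)N1CCC(c2nccnc2OC2CN(c3ccc4ccccc4n3)C2)CC1` has not yet been measured. It differs from compound 2 in one place: 1-(methylsulfonyl)piperidin-4-yl in place of 4-cyanopiperidin-1-yl on an aromatic carbon. Within the data shown here, no measured pair records such a change, so its effect can only be estimated. The expected change, a 1.2-fold higher number from compound 2 to compound 3 (0.08 log units; within the scatter), is small and may not exceed the scatter. Compound 3 is therefore estimated at 80000 nM in this assay, with a likely range from 25000 nM to 250000 nM.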

Compound 3, solubility: 181000 nM
Compound 3: the middle estimate sits 2.3-fold (0.35 log units) below what was measured, and the stated range covers the measured number.
By their numbers in this assay, from the lowest: compound 1; then compound 2; then compound 3.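

Going by these compounds alone, this is the first comparison that changes only one place. In this assay, exchanging the 4-cyanopiperidin-1-yl arm for a 1-(methylsulfonyl)piperidin-4-yl arm next to the ring nitrogen gives a 2.7-fold higher number from compound 2 to compound 3 (0.44 log units; beyond the scatter). The two arms have the same counts of hydrogen-bond donors and acceptors and no net charge, so those counts do not separate them, and nothing available accounts for the rise.

This single step cannot separate the contribution of the methylsulfonyl group from that of the way the piperidine ring is attached. Also open, going by these compounds, is how this read-out would respond at the same position to a different arm, such as a morpholine ring or a piperidine ring carrying an amine or a carboxylic acid.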